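Capping the chain end of compound 3 with dimethylamino

The source may report more compounds than this note shows. Statements on the series, on what has been measured and on what is new or still open speak of the compounds shown alone.

Compound 1 `O=C(NCc1ccc(F)cc1)c1nc(Br)c2cccnc2c1NCCCNc1c(C(=O)NCc2ccc(F)cc2)nc(Br)c2cccnc12`: > 20000 nM (a limit)
Compound 2 `C[C@@H](Nc1c(C(=O)NCc2ccc(F)cc2)nc(Br)c2cccnc12)c1ccccc1`: > 20000 nM (a limit)
Compound 3 `NCCCNc1c(C(=O)NCc2ccc(F)cc2)nc(Br)c2cccnc12`: 5000 nM

Among the compounds with values here, all three results come from a functional assay on MDA-MB-435 cells (Homo sapiens) for cytotoxicity, read by MTT assay, with a stated time of 72 h (a higher number here means a weaker inhibitor, a lower number a stronger inhibitor), where compound 3 gives 5000 nM, the only true number available. The other two results are limits, not numbers: the limit of > 20000 nM in this assay, at which 2 of the 3 values shown sit.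

Compound 4 `CN(C)CCCNc1c(C(=O)NCc2ccc(F)cc2)nc(Br)c2cccnc12` differs from compound 3 at the end of its chain: dimethylamino in place of amino on a saturated chain carbon, three bonds along the chain from a nitrogen on an aromatic ring. In words, this is dimethylamino in place of amino on a saturated chain carbon, three bonds along the chain from a nitrogen on an aromatic ring.

Within the data shown here, only one measured step bears on this, and only loosely: an at least 4.0-fold lower number from compound 2 to compound 3 (0.60 log units; beyond the scatter). That step exchanges a whole group, 3-aminopropyl in place of 1-phenylethyl, and leaves the amino end of the chain unexplored. It therefore suggests no direction for the new change, and a large shift is not expected.

The expected change is a 1.3-fold lower number from compound 3 to compound 4 (0.10 log units; within the scatter), which would be no step beyond the scatter. For compound 4 the estimated value is 4000 nM, with an expected range of 1200 nM to 14000 nM.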

Compound 4, half-maximal inhibitory concentration: 7000 nM
Estimate against measurement, compound 4: 1.8-fold (0.24 log units) below; the measured number falls inside the stated range.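

In this assay, the swap at the chain end removes the hydrogen-bond donor counted on amino and adds two carbons, yet it gives a 1.4-fold higher number from compound 3 to compound 4 (0.15 log units; within the scatter), so this position tolerates dimethylamino as well as amino in this cell test. The advantage of the aminopropyl-type chain over 1-phenylethyl also remains with the capped amine, as shown by an at least 2.8-fold lower number from compound 2 to compound 4 (0.45 log units; beyond the scatter). The value of compound 2 is a limit and not a number: the limit of > 20000 nM in this assay, at which 2 of the 4 values shown sit.

Still open, on these data alone, is whether methylamino, which lies between the two groups compared here, would also leave the number unchanged. As far as these compounds go, it is equally open whether a morpholine ring or a carboxylic acid at the chain end, or a longer chain, would give a step beyond the scatter.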